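A Methyl Step Repeated on a Second Core

This account rests on a few compounds, and the source may have more. Where it says the series, first, only, none or still open, it means among the compounds named here.

Compound 1 `C/C(=C\c1cc(-c2ccccc2)co1)C(N)=O` gives in a functional assay on A549 cells (Homo sapiens) for cytotoxicity, read by CCK-8 assay, with a stated time of 24 h; on this read-out higher numbers stand for weaker inhibition and lower numbers for stronger inhibition > 50000 nM, which is a limit of the assay and not a number.
Compound 2 `C/C(=C\c1cc(-c2ccc(C)cc2)co1)C(N)=O` gives in this assay > 50000 nM, again a limit.
Compound 3 `C/C(=C\c1cc(-c2ccccc2)cs1)C(N)=O` gives in this assay > 50000 nM, also a limit.

Compound 1 and compound 2 differ by methyl in place of hydrogen on an aromatic carbon. The step that the two limits leave unreadable from compound 1 to compound 2 cannot be read, since both values are limits. The difference between the two cores of compound 1 and compound 3 is not broken down here. Among the measured compounds shown here, compound 4 `C/C(=C\c1cc(-c2ccc(C)cc2)cs1)C(N)=O` is not yet measured; it differs from compound 3 by methyl in place of hydrogen on an aromatic carbon, the same change as the one between compound 1 and compound 2, at the same kind of place.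

For the measured compounds named here, all three measured values sit at the limit of > 50000 nM in this assay, at which 3 of the 3 values shown sit, so nothing measured so far distinguishes the compounds. The expected step from compound 3 to compound 4 is a step that the limit leaves unreadable from compound 3 to compound 4, an expectation resting on a step that the two limits leave unreadable from compound 1 to compound 2 being unreadable and on (the limit of > 50000 nM in this assay, at which 3 of the 3 values shown sit). For compound 4 the estimate is 80000 nM, expected to fall between 30000 nM and 300000 nM, most likely reported again only as a limit.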

Compound 4, half-maximal inhibitory concentration: > 50000 nM
Compound 4: a limit, no number; the forecaster's own chance of this, stated with the estimate: 85%; the middle value lies beyond the limit too.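

Compound 3 and compound 4 both stand at a limit of the assay and not at a number, so no step can be read between them. The compounds shown leave open whether the added methyl or the difference between the two cores changes cytotoxicity at all, because every value rests at the same point: the limit of > 50000 nM in this assay, at which 4 of the 4 values shown sit.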